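This account rests on a few compounds, and the source may have more. Where it says the series, first, only, none or still open, it means among the compounds named here.

Compound 1, `CC(C)=CCC/C(C)=C/COc1cc(=O)n(CCCO)c2c1CC(C/C=C(\C)CCC=C(C)C)C(C)(C)C2`: 3.1%
Compound 2, `CC(C)=CCC/C(C)=C/CC1Cc2c(OCCCOc3ccc(Cl)cc3)cc(=O)n(CCCO)c2CC1(C)C`: 0%

In a functional assay on PANC-1 cells (Homo sapiens) for inhibition, read by MTT assay, with a stated time of 24 h, tested at 10 uM (a lower number here means less inhibition, a higher number more inhibition at the concentration tested (going by the name of the read-out)), compound 1 gives 3.1% and compound 2 gives 0%. Among the measured compounds shown here, on these two numbers compound 2 sits alongside compound 1, since the only measured step, a number 3.1 percentage points lower from compound 1 to compound 2 (within the scatter), is within the scatter, and neither compound shows inhibition of any size at the concentration tested.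

Compound 3, `CC(C)=CCC/C(C)=C/CC1Cc2c(OCCCOc3ccc([N+](=O)[O-])cc3)cc(=O)n(CCCO)c2CC1(C)C`, differs from compound 2 by nitro in place of chloro on an aromatic carbon. For the measured compounds named here, no measured step touches this aromatic substituent: the one step available, a number 3.1 percentage points lower from compound 1 to compound 2 (within the scatter), concerns the chain on the ring oxygen and was itself within the scatter. With both measured numbers close to zero, compound 3 is expected to show a step of a number 3 percentage points higher from compound 2 to compound 3 (within the scatter) in this assay, that is, none beyond the scatter. Compound 3 is therefore estimated at 3%, with a range from 0% to 12%.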

Compound 3, a percentage reported as inhibition, at one concentration (the size of the read-out at that concentration, not a potency): 9.8%
For compound 3 the middle estimate is 6.8 percentage points below the measured one; the range from low to high includes it.
By their numbers in this assay, from the lowest: compounds 2, 1 and 3 (each within the scatter of the next).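

Among the compounds shown here, with nitro in place of chloro on an aromatic carbon, para to a large group, the aromatic ring is varied for the first time, and in this assay this gives a number 9.8 percentage points higher from compound 2 to compound 3 (within the scatter), so exchanging these two groups does not separate compound 2 and compound 3 at the concentration tested. The step of 2-(4-nitrophenoxy)ethyl in place of 2,6-dimethylhepta-1,5-dien-1-yl gives a number 6.7 percentage points higher from compound 1 to compound 3 (within the scatter), so compound 1 and compound 3 are not separated either. No available measurement bears on the reason for these numbers.

The compounds shown leave open whether an amine or a carboxylic acid in this place on the aromatic ring would give a number beyond the scatter. They also leave open whether a longer chain carrying the 4-nitrophenoxy group would do so.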